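Compound 2 and the Fluoro Step

The compounds below may be only part of what the source reports. "The series", "measured", "known", "first", "only" and "open" are said of these compounds alone.

Compound 1: `COc1ccc(Cc2cn3cc(Br)ccc3nc2=O)cc1` at 940 nM
Compound 2: `Nc1cccn2cc(Cc3ccccc3)c(=O)nc12` at 116000 nM

In a functional assay on SK-N-SH cells (Homo sapiens) for cytotoxicity, read by MTT assay, with a stated time of 24 h (a higher number here means a weaker inhibitor, a lower number a stronger inhibitor), compound 2 stands highest of the two numbers, beyond the scatter from compound 1 and therefore the weaker inhibitor of the pair. Compound 3 `Nc1cccn2cc(Cc3ccc(F)cc3)c(=O)nc12` differs from compound 2 by a single change (fluoro in place of hydrogen on an aromatic carbon): fluoro in place of hydrogen on an aromatic carbon, para to a large group. For the measured compounds named here, no measured pair shows the size of such a change, and no step beyond the scatter is expected in this assay here. The estimated step is a 1.3-fold lower number from compound 2 to compound 3 (0.11 log units; within the scatter) and is expected to lie toward a slightly lower number. Compound 3 is estimated at 90000 nM (range 35000 nM to 200000 nM).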

Compound 3, half-maximal inhibitory concentration: 126000 nM
Compound 3: middle estimate off by 1.4-fold (0.15 log units), on the low side; the range from low to high includes it.
By their numbers in this assay, from the lowest: compound 1; then compounds 2 and 3 (each within the scatter of the next).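

In this assay, fluoro in place of hydrogen on an aromatic carbon, para to a large group, gives a 1.1-fold higher number from compound 2 to compound 3 (0.04 log units; within the scatter) and so leaves the number within the scatter. For the compounds shown here, this pair is the first measured size for the change, and it shows that this position tolerates the added fluorine without a step beyond the scatter. Nothing measured here bears on a cause for this result. The compounds shown leave open whether an amine or a carboxylic acid in the same place would give a step beyond the scatter.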